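A few compounds are considered here, and "the series" means these few. Any claim that something is new, unique, unknown or untested is made for them only; others in the source may bear on it.

In a functional assay on HT-1080 cells (Homo sapiens) for cytotoxicity, read by MTT assay, with a stated time of 72 h (a higher number here means a weaker inhibitor, a lower number a stronger inhibitor), compound 1 (`COc1ccc(/C=C2\CCC/C(=C\c3ccc(Br)cc3)C2=O)cc1OC`) gives 4300 nM and compound 2 (`COc1ccc(/C=C2\CCC/C(=C\c3ccc(OC)c(OC)c3)C2=O)cc1`) gives 7200 nM while compound 3 (`COc1ccc(/C=C2\CCC/C(=C\c3ccc(O)cc3)C2=O)cc1OC`) gives 16800 nM and so stands as the weakest of the three. Compound 4 (`COc1ccc(/C=C2\CCC/C(=C\c3ccc(O)c(O)c3)C2=O)cc1OC`) makes one change to compound 3 (hydroxy in place of hydrogen on an aromatic carbon): 4-hydroxyphenyl becomes 3,4-dihydroxyphenyl. Two measured steps involve a hydroxy group. The step of a 3.9-fold higher number from compound 1 to compound 3 (0.59 log units; beyond the scatter) puts hydroxy in place of bromo, and the step of a 2.3-fold higher number from compound 2 to compound 3 (0.37 log units; beyond the scatter) puts hydrogen in place of methyl on an oxygen. Both are modest and both raise the number, yet neither adds hydroxy where a hydrogen stood, so they offer only weak guidance and no change beyond the scatter is expected. The expected step is a 1.3-fold lower number from compound 3 to compound 4 (0.11 log units; within the scatter) and remains an estimate. Compound 4 is expected at 13000 nM within a range from 4500 nM to 35000 nM in this measurement.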

Compound 4, half-maximal inhibitory concentration: 4200 nM
Beside the measured number, compound 4's estimate is 3.1-fold (0.49 log units) above it; the whole stated range lies above it.
By their numbers in this assay, from the lowest: compounds 4, 1 and 2 (each within the scatter of the next); then compound 3.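

In this assay, a 4.0-fold lower number from compound 3 to compound 4 (0.60 log units; beyond the scatter), so hydroxy in place of hydrogen on this aromatic carbon, ortho to a hydroxy group, lowers the number, whereas the earlier hydroxy steps raised it. With a 1.7-fold lower number from compound 2 to compound 4 (0.23 log units; within the scatter) and a 1.0-fold lower number from compound 1 to compound 4 (0.01 log units; within the scatter), both within the scatter, the 3,4-dihydroxyphenyl compound is level with compounds that carry no hydroxy group, so a hydroxy group on this ring does not always go with a higher number. No measurement shown here gives a reason for this change. On these data alone, whether an amine or a carboxylic acid at this position would also lower the number remains open.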